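Swapping Fluoro for Dimethylamino on a Bromo-Bearing Ring

The compounds below may be only part of what the source reports. "The series", "measured", "known", "first", "only" and "open" are said of these compounds alone.

Compound 1, `Cc1cc2c(c(=O)n1C)C(c1ccc(C(C)C)cc1)C(C#N)=C(N)O2`: > 100000 nM
Compound 2, `Cc1cc2c(c(=O)n1C)C(c1ccc(F)c(Br)c1)C(C#N)=C(N)O2`: 6330 nM

Of the compounds shown here, two sharing one core have been tested in a functional assay on HeLa cells (Homo sapiens) for antiproliferative activity, read by MTT assay, with a stated time of 48 h; on this read-out higher numbers stand for weaker inhibition and lower numbers for stronger inhibition. Compound 1 `Cc1cc2c(c(=O)n1C)C(c1ccc(C(C)C)cc1)C(C#N)=C(N)O2` reaches only > 100000 nM, which is a limit of this assay rather than a number. That result sits at the limit of > 100000 nM in this assay, at which 1 of the 2 values shown sits. Within the data shown here, compound 2 `Cc1cc2c(c(=O)n1C)C(c1ccc(F)c(Br)c1)C(C#N)=C(N)O2` gives 6330 nM in this assay, and of the two results it is the only one that is a number. Compound 3 `Cc1cc2c(c(=O)n1C)C(c1ccc(N(C)C)c(Br)c1)C(C#N)=C(N)O2` has not yet been measured; it differs from compound 2 by dimethylamino in place of fluoro on an aromatic carbon.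

Among the measured compounds shown here, no pair of measured compounds differing in one place is available, so there is no reference for how large such a change usually is here. The step from compound 2 to compound 3 is expected to be a 1.4-fold higher number from compound 2 to compound 3 (0.15 log units; within the scatter), a shift that may fall within the usual scatter or lean toward weaker inhibition. Compound 3 is therefore estimated at 9000 nM, with a range from 2000 nM to 40000 nM.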

Compound 3, half-maximal inhibitory concentration: 330 nM
For compound 3 the middle estimate is 27-fold (1.44 log units) above the measured one; measured number outside the range, below it.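

In this assay, putting dimethylamino in place of fluoro on the aromatic carbon ortho to a bromo group gives a 19-fold lower number from compound 2 to compound 3 (1.28 log units; beyond the scatter) and moves the result toward stronger inhibition. With only this one place changed, the step shows that the group held on this carbon can matter a great deal on this read-out, something that compounds 1 and 2 could not show on their own. Nothing measured here explains the size of this step.

Which part of dimethylamino carries the step stays open, and a plain amino group, a methoxy group or a pyrrolidine ring on the same carbon would help to separate the possibilities. On these data alone, it is also open whether dimethylamino would have a similar effect if a chlorine atom or a hydrogen atom stood in place of the bromo group.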